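Removing the aryl ethyl group from the benzyl side of compound 3

The source may report more compounds than this note shows. Statements on the series, on what has been measured and on what is new or still open speak of the compounds shown alone.

Measured in a functional assay for inhibition, with Rattus norvegicus as the target; a lower number here means a stronger inhibitor, a higher number a weaker inhibitor:
- compound 1, `CCC(C)(C)/N=c1\c(O)c(O)\c1=N/Cc1ccc(SC)cc1`: 5600 nM
- compound 2, `CCCC/N=c1\c(O)c(O)\c1=N/Cc1ccc(C#N)cc1`: reaches only the assay limit, > 30000 nM
- compound 3, `CCc1cc(C#N)ccc1C/N=c1\c(O)c(O)\c1=N/C(C)(C)CC`: 110 nM

Compound 3 holds the lowest of the two numbers in this assay; compound 1 sits well beyond the scatter from it, and compound 2 gives no number at all, only the limit (the limit of > 30000 nM in this assay, at which 1 of the 3 values shown sits).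

Compound 4, `CCC(C)(C)/N=c1\c(O)c(O)\c1=N/Cc1ccc(C#N)cc1`, is not yet measured. It differs from compound 3 by hydrogen in place of ethyl on an aromatic carbon. For the measured compounds named here, no measured pair isolates this change. Compound 2 and compound 1, which both lack the ethyl group, show far weaker inhibition than compound 3, though each also differs from it elsewhere. A loss of potency beyond the scatter is therefore expected from compound 3 to compound 4, estimated at a 27-fold higher number from compound 3 to compound 4 (1.44 log units; beyond the scatter). Compound 4 is estimated at 3000 nM in this assay, with a range from 500 nM to 20000 nM.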

Compound 4, half-maximal inhibitory concentration: 1100 nM
Estimate against measurement, compound 4: 2.7-fold (0.44 log units) above; measured number inside the range.
By their numbers in this assay, from the lowest: compound 3; then compound 4; then compound 1. At a limit, above all of these: compound 2.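

In this assay, the ethyl group on the aromatic carbon ortho to a large group and meta to a cyano group now has a step of its own: hydrogen in place of ethyl gives a 10-fold higher number from compound 3 to compound 4 (1.00 log units; beyond the scatter). Compound 4 also isolates the group on the other side of the benzyl ring's aromatic carbon, where cyano in place of methylsulfanyl gives a 5.1-fold lower number from compound 1 to compound 4 (0.71 log units; beyond the scatter). On the double-bonded nitrogen, 1,1-dimethylpropyl in place of butyl gives an at least 27-fold lower number from compound 2 to compound 4 (1.43 log units; beyond the scatter), a step read against a limit of compound 2 and not a number: the limit of > 30000 nM in this assay, at which 1 of the 4 values shown sits.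

Open, as far as these compounds go, is whether a methyl group, a propyl chain or a methoxy group on that aromatic carbon would match ethyl. Also open, from the compounds shown here alone, is whether the ethyl step keeps its size with butyl on the double-bonded nitrogen.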